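This account rests on a few compounds, and the source may have more. Where it says the series, first, only, none or still open, it means among the compounds named here.

Among the three compounds measured so far, compound 3 `COC(=O)C1=C(C)N=C(C)/C(=C(\O)OC)C1c1cccc(C)c1` gives the lowest number: in a functional assay (muscle tissue) with Cavia porcellus as the target (a higher number here means that more compound is needed for the effect, a lower number that less compound is needed), compound 3 gives 110 nM, while compound 1 `COC(=O)C1=C(C)N=C(C)/C(=C(\O)OC)C1c1cccc(OC(C)=O)c1` gives 6030 nM and compound 2 `COC(=O)C1=C(C)N=C(C)/C(=C(\O)OC)C1c1ccc(I)cc1` gives 22900 nM. Both gaps are beyond the scatter, so compound 3 is the most potent of the three.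

Compound 4 `COC(=O)C1=C(C)N=C(C)/C(=C(\O)OC)C1c1cccc(O)c1` differs from compound 3 in one place: hydroxy in place of methyl on an aromatic carbon. The step that bears on this is a 55-fold lower number from compound 1 to compound 3 (1.74 log units; beyond the scatter), where an oxygen-linked group on the same aromatic carbon was replaced by methyl. Reversing that idea, the hydroxy group of compound 4 is expected to raise the number, though the small hydroxy need not match the full size of that step. Compound 4 is therefore estimated at 1500 nM, with a range of 300 nM to 8000 nM, a step of a 14-fold higher number from compound 3 to compound 4 (1.13 log units; beyond the scatter).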

Compound 4, half-maximal effective concentration: 1000 nM
Compound 4: the middle estimate sits 1.5-fold (0.18 log units) above what was measured; the measured number falls inside the stated range.
By their numbers in this assay, from the lowest: compound 3; then compound 4; then compound 1; then compound 2.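

In this assay, hydroxy in place of methyl on this aromatic carbon gives a weaker result (a 9.1-fold higher number from compound 3 to compound 4 (0.96 log units; beyond the scatter)), yet removing the acetyl from the oxygen gives a stronger one (a 6.0-fold lower number from compound 1 to compound 4 (0.78 log units; beyond the scatter)), so the free hydroxy falls between methyl and acetoxy. Compound 4 also keeps a wide lead when its 3-hydroxyphenyl replaces 4-iodophenyl (a 23-fold lower number from compound 2 to compound 4 (1.36 log units; beyond the scatter)). Nothing measured here explains these differences. The compounds shown leave open how an amine, a fluorine or an ethyl group on this same carbon would compare with methyl and hydroxy.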